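Histamine H2 agonist series: pyridyl in place of chlorophenyl

The compounds below may be only part of what the source reports. "The series", "measured", "known", "first", "only" and "open" are said of these compounds alone.

Measured so far:
compound 1 `N=C(NCCCc1c[nH]cn1)NCCCC(c1ccc(F)cc1)c1ccccn1` gives 6.87
compound 2 `COc1ccc(C(CC/N=C(\N)NCCCc2c[nH]cn2)c2ccccn2)cc1` gives 7.44
compound 3 `N=C(NCCCc1c[nH]cn1)NCCC(c1ccc(Cl)cc1)c1ccccn1` gives 7.84

All three values come from a functional assay on cardiac atrium for agonist activity at histamine H2 receptor (Cavia porcellus); a higher number here means a more potent compound, by a factor of ten per unit of this negative logarithm, a lower number a less potent compound. Compound 3 stands highest of the three; compound 2 lies beyond the scatter below it, and compound 1 lies further below, also beyond the scatter. For the measured compounds named here, no single-point step between measured compounds is available, so the size of any one change must be judged from the whole set.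

Compound 4 `N=C(NCCCc1c[nH]cn1)NCCC(c1ccccn1)c1ccccn1` is not yet measured. It differs from compound 3 as follows: pyridin-2-yl in place of 4-chlorophenyl on a saturated chain carbon bound to an aromatic carbon and a saturated chain carbon. On the evidence of compound 3 at 7.84 as the best of the set, a step downward, beyond the scatter, is expected. The estimate for compound 4 in this assay is 7.3, within 6.7 to 7.9, which means an expected step of a number 0.54 log units lower from compound 3 to compound 4 (beyond the scatter).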

Compound 4, negative logarithm of the half-maximal effective concentration: 6.9
Beside the measured number, compound 4's estimate is 0.40 log units above it; low and high end bracket the measured number.
By their numbers in this assay, from the lowest: compounds 1 and 4 (each within the scatter of the next); then compound 2; then compound 3.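

In this assay, for the compounds shown here, pyridin-2-yl in place of 4-chlorophenyl on this saturated chain carbon gives a number 0.94 log units lower from compound 3 to compound 4 (beyond the scatter) and is the first step that isolates a single place. The position therefore responds to the identity of this aromatic group, and a second pyridin-2-yl does not stand in for 4-chlorophenyl. Nothing at hand bears on what lies behind the step.

Open, from the compounds shown here alone, is how pyridin-3-yl or 3,4-dichlorophenyl would read on this carbon. Also open, going by these compounds, is whether the same exchange gives a step of similar size when the chain is longer, as in compound 1.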